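Phenyl in place of propyl on a shared core

The source may hold more compounds than are shown below. What is called first, only, known or untested is meant among the compounds shown, and "the series" means these compounds.

Compound 1, `CCCc1nc(C)c2c(C(C)C)nnc(O)n12`, in a functional assay for inhibition, with Homo sapiens as the target; on this read-out lower numbers stand for stronger inhibition and higher numbers for weaker inhibition: > 48000 nM
Compound 2, `CCCc1nc(C)c2c(-c3ccccc3)nnc(SC)n12`, in this assay: > 48000 nM
Compound 3, `CCCc1nnc(O)n2c(CCC)nc(C)c12`, in this assay: 16000 nM

In this assay, among the measured compounds shown here, compound 3 gives 16000 nM, the only number among the three. The values of compound 1 and compound 2 are limits of the assay. For compound 1 the value > 48000 nM is such a limit. For compound 2 the value > 48000 nM is such a limit as well. Compound 4, `CCCc1nc(C)c2c(-c3ccccc3)nnc(O)n12`, differs from compound 3 in one place: phenyl in place of propyl on an aromatic carbon.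

For the measured compounds named here, only one measured step touches the same position: an at least 3.0-fold lower number from compound 1 to compound 3 (0.47 log units; beyond the scatter). That step shows that a change at this carbon can move the number, but it does not concern a phenyl. Going by the values given here, compound 2, which carries a phenyl at this position, sits at the limit of > 48000 nM in this assay, at which 2 of the 3 values shown sit; it also differs from compound 4 in the thiomethyl in place of the hydroxy, so no step can be drawn from it. Compound 4 is therefore expected to lie near the limit, with a step of a 2.5-fold higher number from compound 3 to compound 4 (0.40 log units; beyond the scatter). The estimate for compound 4 in this assay is 40000 nM, within 10000 nM to 120000 nM.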

Compound 4, half-maximal inhibitory concentration: > 48000 nM
Compound 4: no number, only a limit; the forecaster's own chance of this, stated with the estimate: 55%; middle value at least 1.2-fold (0.07 log units) away from the limit.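

In this assay the phenyl now has a readable step of its own, an at least 3.0-fold higher number from compound 3 to compound 4 (0.47 log units; beyond the scatter), so with the hydroxy group kept on the shared core, phenyl in place of propyl on this aromatic carbon weakens inhibition by a margin beyond the usual scatter. The value of compound 4, > 48000 nM, is a limit. The steps to compound 4 from compound 1 and from compound 2 cannot be read, and compound 3 stays the only compound with a number: the limit of > 48000 nM in this assay, at which 3 of the 4 values shown sit.

As far as these compounds go, whether a longer chain such as butyl, or an amine, on this carbon would give a lower number than the propyl of compound 3 remains open. Also open, from the compounds shown here alone, is whether a methoxy group on the phenyl of compound 4 would bring a readable number.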